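The source may hold more compounds than are shown below. What is called first, only, known or untested is meant among the compounds shown, and "the series" means these compounds.

Compound 1, `COc1nc(-c2ccc(C#N)cc2)ccc1[C@@H](c1ccccc1)[C@@](O)(CCN(C)C)c1cccc2ccccc12`: in a toxicity assay on HeLa cells (Homo sapiens) for cytotoxicity (a lower number here means that less compound is tolerated, a higher number that more compound is tolerated), compound 1 gives > 64 ug/mL, which is a limit of the assay and not a number.
Compound 2, `COc1nc(-c2ccncc2)ccc1[C@@H](c1ccccc1)[C@@](O)(CCN(C)C)c1cccc2ccccc12`: in this assay compound 2 gives 9.6 ug/mL.

Among the compounds with values here, compound 2 therefore holds the only real number in this assay. The other value shown, that of compound 1, is a limit. Within the data shown here, the single measured step, an at least 6.6-fold lower number from compound 1 to compound 2 (0.82 log units; beyond the scatter), came with pyridin-4-yl in place of 4-cyanophenyl on an aromatic carbon of the shared core.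

Compound 3, `COc1nc(-c2ccc(Br)cc2)ccc1[C@@H](c1ccccc1)[C@@](O)(CCN(C)C)c1cccc2ccccc12`, has not yet been tested in this assay. It differs from compound 2 as follows: 4-bromophenyl in place of pyridin-4-yl on an aromatic carbon. The entering 4-bromophenyl, like the 4-cyanophenyl of compound 1, is a six-membered aromatic ring of carbon only, so the step of an at least 6.6-fold lower number from compound 1 to compound 2 (0.82 log units; beyond the scatter) bears on this change in reverse and points back toward (the limit of > 64 ug/mL in this assay, at which 1 of the 2 values shown sits). A rise beyond the scatter is expected, a 4.2-fold higher number from compound 2 to compound 3 (0.62 log units; beyond the scatter), though the size of the return is uncertain because compound 1 sits at the limit of > 64 ug/mL in this assay, at which 1 of the 2 values shown sits. Compound 3 is expected to give 40 ug/mL in this assay, within a range from 15 ug/mL to 110 ug/mL.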

Compound 3, half-maximal cytotoxic concentration: > 64 ug/mL
Compound 3: only a limit was reported; the forecaster's own chance of this, stated with the estimate: 45%; at least 1.6-fold (0.20 log units) between middle value and limit.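

The change to 4-bromophenyl gives an at least 6.6-fold higher number from compound 2 to compound 3 (0.82 log units; beyond the scatter). Among these three compounds, the two with a six-membered aromatic ring of carbon only at this position, on an aromatic carbon next to the ring nitrogen, both reach the limit, while compound 2, with pyridin-4-yl, alone has a real number in this assay, so the high reading of compound 1 does not depend on its nitrile alone. The step between the nitrile of compound 1 and the bromo of compound 3 cannot be read, and neither compound can be placed above the other, as neither has a real number: the limit of > 64 ug/mL in this assay, at which 2 of the 3 values shown sit.

The compounds shown leave open whether the lower number in compound 2 follows the ring nitrogen in general, as a pyridin-3-yl or a pyrimidin-5-yl ring could show, or belongs to pyridin-4-yl alone. They also leave open whether a plain phenyl ring, or a phenyl ring carrying an amine or a carboxylic acid, would give a real number in this assay or stay at the limit.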